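The source may hold more compounds than are shown below. What is called first, only, known or untested is meant among the compounds shown, and "the series" means these compounds.

In a functional assay on A549 cells (Homo sapiens) for inhibition, read by MTT assay, with a stated time of 72 h (on this read-out higher numbers stand for weaker inhibition and lower numbers for stronger inhibition), compound 1 (`Nc1ncnc2c1c(-c1cnc3[nH]ccc3c1)nn2CC(=O)NO`) reads > 150000 nM and this is a limit of the assay. Going by the values given here, compound 2 (`Nc1ncnc2c1c(-c1cnc3[nH]ccc3c1)nn2CCCCCCCCC(=O)NO`) gives 12300 nM as the only true number so far. Compound 3 (`Nc1nc2cc(-c3nn(CCCCC(=O)NO)c4ncnc(N)c34)ccc2o1`) stands at > 100000 nM and this too is only a limit, so it has no exact place on the scale.

The next compound is compound 4 (`Nc1nc2cc(-c3nn(CCCCCCC(=O)NO)c4ncnc(N)c34)ccc2o1`). Its change from compound 3 is 2-(hydroxycarbamoyl)ethyl in place of hydroxycarbamoyl on a saturated chain carbon, four bonds along the chain from an aromatic nitrogen on a saturated chain carbon, four bonds along the chain from an aromatic nitrogen. The same difference reads as 3-(hydroxycarbamoyl)propyl to 5-(hydroxycarbamoyl)pentyl.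

Among the compounds with values here, no measured pair isolates this change. The nearest guide is compound 2 at 12300 nM with a chain longer than that of compound 4, though its remaining core differs. The step expected in this assay is an at least 2.8-fold lower number from compound 3 to compound 4 (0.45 log units; beyond the scatter) toward stronger inhibition, an estimate made against a limit. For compound 4 the estimated value is 35000 nM with an expected range of 10000 nM to 120000 nM in this assay.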

Compound 4, half-maximal inhibitory concentration: 33000 nM
Compound 4: the middle estimate sits 1.1-fold (0.03 log units) above what was measured, within the range that was stated.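

Going by these compounds alone, replacing hydroxycarbamoyl with 2-(hydroxycarbamoyl)ethyl on a saturated chain carbon, four bonds along the chain from an aromatic nitrogen, gives the first exact number on the core of compound 3: in this assay the change is an at least 3.0-fold lower number from compound 3 to compound 4 (0.48 log units; beyond the scatter), toward stronger inhibition. This is the only step shown between compounds that differ in one place, so it is the first direct reading of chain length at this position. Compound 3 gives only a limit, so the size of this step is a bound and not a number: the limit of > 100000 nM in this assay, at which 1 of the 4 values shown sits.

On these data alone, whether a longer chain on this core moves the number further in the same direction remains open. Also open, as far as these compounds go, is how a carboxylic acid in place of the hydroxycarbamoyl at the chain end would read on the same chain.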